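Moving the fluorine: from compound 3 to compound 4

The compounds below may be only part of what the source reports. "The series", "measured", "known", "first", "only" and "open" are said of these compounds alone.

Measured compounds:
compound 1 `Cc1ccc(C)c(N2CCN(C(=O)c3oc(C)nc3-c3ccccc3)CC2)c1` — 31.3 nM
compound 2 `CC(=O)c1ccc(N2CCN(C(=O)c3oc(C)nc3-c3ccccc3)CC2)cc1` — "not active" (no number reported)
compound 3 `Cc1nc(-c2ccccc2)c(C(=O)N2CCN(c3ccc(F)cc3)CC2)o1` — > 1000 nM

In a functional assay on HL-60 cells (Homo sapiens) for inhibition, read by MTT assay, with a stated time of 72 h (on this read-out lower numbers stand for stronger inhibition and higher numbers for weaker inhibition), compound 1 gives 31.3 nM, while compound 2 gives "not active" (no number reported). For compound 3 only a limit of the assay is known, > 1000 nM; this is the limit of > 1000 nM in this assay, at which 1 of the 3 values shown sits, and compound 2 is the further entry without a single number. For the measured compounds named here, the one measured step, an at least 31-fold higher number from compound 1 to compound 3 (1.50 log units; beyond the scatter), exchanges the whole aryl group and does not isolate the fluorine position. Compound 4 `Cc1nc(-c2ccccc2)c(C(=O)N2CCN(c3cccc(F)c3)CC2)o1` differs from compound 3 by 3-fluorophenyl in place of 4-fluorophenyl on an amine nitrogen in a ring. Going by the values given here, no measured step bears directly on this change, and nothing suggests a step beyond the scatter in this assay. Compound 4 is estimated at 3000 nM (range 800 nM to 15000 nM), an expected step that the limit leaves unreadable from compound 3 to compound 4.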

Compound 4, half-maximal inhibitory concentration: 45 nM
Compound 4: middle estimate off by 67-fold (1.82 log units), on the high side, outside the stated range (below it).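

In this assay, moving the fluorine alone, with the same atoms joined differently, gives an at least 22-fold lower number from compound 3 to compound 4 (1.34 log units; beyond the scatter). Compound 3 stands at a limit of the assay, not at a number: the limit of > 1000 nM in this assay, at which 1 of the 4 values shown sits. Exchanging 2,5-dimethylphenyl for 3-fluorophenyl gives a 1.4-fold higher number from compound 1 to compound 4 (0.16 log units; within the scatter), so the two groups cannot be told apart on this read-out.

The compounds shown leave open whether a chlorine or a methoxy group in place of the fluorine of compound 4 would keep this level of inhibition. They also give no cause for the step between the two fluorophenyl groups.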